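Swapping the halogen-bearing ring on a thiadiazole amide

The source may report more compounds than this note shows. Statements on the series, on what has been measured and on what is new or still open speak of the compounds shown alone.

Measured so far in a functional assay on CHO cells for agonist activity at Free fatty acid receptor 1 (Homo sapiens), read by calcium flux; on this read-out lower numbers stand for an effect already at smaller amounts and higher numbers for an effect only at larger amounts of compound:
compound 1 `O=C(O)CCc1nnc(C(=O)Nc2cccc(-c3ccco3)c2)s1` gives 1640 nM
compound 2 `O=C(O)CCc1ccc(OCc2nnc(C(=O)Nc3ccccc3F)s2)cc1` gives 580 nM

Of these two, compound 2 has the lower number in this assay, and its gap to compound 1 lies beyond the usual scatter of repeated measurements. Compound 3 `O=C(O)CCc1ccc(OCc2nnc(C(=O)Nc3cccc(Cl)c3)s2)cc1` has not yet been measured. It differs from compound 2 in a single place: 3-chlorophenyl in place of 2-fluorophenyl on an amide-type nitrogen. Among the measured compounds shown here, no measured pair shows this change, so its size cannot be read off from the numbers in hand. The rest of the molecule stays the same, and compound 2 already carries the lower of the two known values, so for compound 3 only a small step is expected, a 1.5-fold lower number from compound 2 to compound 3 (0.16 log units; within the scatter), probably within the scatter, with a slight lean toward a lower number. Compound 3 is therefore estimated at 400 nM in this assay, with a range from 150 nM to 1200 nM.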

Compound 3, half-maximal effective concentration in the Free fatty acid receptor 1 assay: 10600 nM
The estimate for compound 3 lay 27-fold (1.42 log units) below the measured number; the measured number lies above the stated range.
By their numbers in the Free fatty acid receptor 1 assay, from the lowest: compound 2; then compound 1; then compound 3.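

The group on the amide-type nitrogen turns out to be a sensitive spot: in the Free fatty acid receptor 1 assay, 3-chlorophenyl in place of 2-fluorophenyl gives an 18-fold higher number from compound 2 to compound 3 (1.26 log units; beyond the scatter). Among the compounds shown here, compound 1 differs from compound 2 in more than one place, so only this pair isolates the group, and it shows that exchanging one halogen-bearing ring for another with the same heavy-atom count can carry a large cost. In a physicochemical assay for lipophilicity, read by LC-MS, at pH 7.4 (on this read-out higher numbers stand for higher lipophilicity and lower numbers for lower lipophilicity), compound 2 gives 0.95 and compound 3 gives 1.46 as its distribution coefficient. The swap also makes the compound more lipophilic in the physicochemical assay, although a single pair cannot show whether this rise is linked to the weaker effect: the measured distribution coefficient of compound 2, 0.95, and of compound 3, 1.46, a number 0.51 log units higher (beyond the scatter)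

The halogen and its place on the ring change together here, so the compounds shown cannot separate the two. As far as these compounds go, how a plain phenyl group or a methoxyphenyl group would behave on this nitrogen also stays open.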